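The compounds below may be only part of what the source reports. "The series", "measured", "known", "first", "only" and "open" are said of these compounds alone.

Two measured compounds share a core: compound 1 `COc1ccc(/C=C/C(=O)c2c(OC)cc(O)c(CC=C(C)C)c2O)cc1OC` and compound 2 `COc1cc(O)c(CC=C(C)C)c(O)c1C(=O)/C=C/c1cccc([N+](=O)[O-])c1`; how their cores differ is not broken down here. In a functional assay on A549 cells (Homo sapiens) for inhibition, read by MTT assay, with a stated time of 72 h (on this read-out lower numbers stand for stronger inhibition and higher numbers for weaker inhibition), compound 1 gives 15700 nM, and compound 2 gives 15000 nM, a pair within the usual scatter. Compound 3 `COc1ccc(/C=C/C(=O)c2c(O)cc(O)cc2OC)cc1OC` arises from compound 1 by one change (hydrogen in place of 3-methylbut-2-en-1-yl on an aromatic carbon). In this assay compound 3 reaches only a limit of the assay, > 50000 nM. The step of an at least 3.1-fold higher number from compound 1 to compound 3 (0.50 log units; beyond the scatter) is at least modest, and its size is bounded by the limit of > 50000 nM in this assay, at which 1 of the 3 values shown sits. Compound 4 `COc1cc(O)cc(O)c1C(=O)/C=C/c1cccc([N+](=O)[O-])c1` arises from compound 2 by the same change (hydrogen in place of 3-methylbut-2-en-1-yl on an aromatic carbon), made here a second time. Because the step of an at least 3.1-fold higher number from compound 1 to compound 3 (0.50 log units; beyond the scatter) ran at least as far as the limit, compound 4 is expected to follow, so the estimated step is a 3.3-fold higher number from compound 2 to compound 4 (0.52 log units; beyond the scatter). Compound 4 is estimated at 50000 nM, between 25000 nM and 100000 nM.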

Compound 4, half-maximal inhibitory concentration: 36800 nM
Compound 4: middle estimate off by 1.4-fold (0.13 log units), on the high side; low and high end bracket the measured number.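

Removing the 3-methylbut-2-en-1-yl group and leaving hydrogen in its place gives a 2.5-fold higher number from compound 2 to compound 4 (0.39 log units; beyond the scatter) in this assay and so weakens inhibition on this second core as well. The direction of the change therefore carries over between the two cores, but whether its size does cannot be said: the same change on two cores in this assay, an at least 3.1-fold higher number (0.50 log units; beyond the scatter) from compound 1 to compound 3 and a 2.5-fold higher number (0.39 log units; beyond the scatter) from compound 2 to compound 4; the limit leaves it open whether they differ. Compound 3 gives only a limit of the assay: > 50000 nM.

The compounds shown leave open whether a methyl group, a saturated pentyl chain or an amine on that aromatic carbon would behave like 3-methylbut-2-en-1-yl or like hydrogen. They also leave open whether the same step holds on any other core.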